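This account rests on a few compounds, and the source may have more. Where it says the series, first, only, none or still open, it means among the compounds named here.

- Compound 1 `O=C(/C=C/c1cccnc1)c1ccccc1`: 7700 nM
- Compound 2 `COc1cccc(C(=O)/C=C/c2cccnc2)c1`: 2300 nM
- Compound 3 `O=C(/C=C/c1cccnc1)c1ccccc1Br`: > 300000 nM, a limit and not a number
- Compound 4 `COc1ccc(C(=O)/C=C/c2cccnc2)cc1`: not yet measured

All values come from an ADME assay on KB cells (Homo sapiens) for cytotoxicity, read by resazurin assay, with a stated time of 72 h; a lower number here means a stronger inhibitor, a higher number a weaker inhibitor. Of the two actual numbers, compound 1 holds the higher. Compound 4 carries methoxy in place of hydrogen on an aromatic carbon of the core of compound 1, para to a large group: methoxy in place of hydrogen on an aromatic carbon. Going by the values given here, two measured steps bear on this change. The same exchange of groups gave a modest step, a 3.3-fold lower number from compound 1 to compound 2 (0.52 log units; beyond the scatter). Bromo in place of hydrogen gave a large one, an at least 38-fold higher number from compound 1 to compound 3 (1.59 log units; beyond the scatter), but involves a different group and so carries less weight. A modest step to a lower number in this assay is therefore expected, resting on a 3.3-fold lower number from compound 1 to compound 2 (0.52 log units; beyond the scatter). The expected step is a 2.2-fold lower number from compound 1 to compound 4 (0.34 log units; beyond the scatter). The estimate for compound 4 is 3500 nM, with an expected range of 1000 nM to 15000 nM.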

Compound 4, half-maximal inhibitory concentration: 21700 nM
Compound 4: the middle estimate sits 6.2-fold (0.79 log units) below what was measured, and the stated range ends below it.
By their numbers in this assay, from the lowest: compound 2; then compound 1; then compound 4. At a limit, above all of these: compound 3.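

In this assay, methoxy para to a large group gives a 2.8-fold higher number from compound 1 to compound 4 (0.45 log units; beyond the scatter), whereas the same exchange of groups in compound 2 gave a 3.3-fold lower number from compound 1 to compound 2 (0.52 log units; beyond the scatter). The direction of this change therefore depends on where methoxy sits on the ring, which compound 2 alone could not show. Nothing measured here accounts for this reversal. On these data alone, it remains open whether the higher number follows from methoxy specifically or from any group para to a large group. An amine or a carboxylic acid in that place would help separate the two.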